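The source may report more compounds than this note shows. Statements on the series, on what has been measured and on what is new or still open speak of the compounds shown alone.

Measured compounds:
compound 1, `C[C@@H](Cn1ccc(-c2ccc(C#N)c(Cl)c2)n1)Nc1cccnc1`, > 30000 nM
compound 2, `C[C@@H](Cn1ccc(-c2ccc(C#N)c(Cl)c2)n1)Nc1cccc2ccncc12`, 5130 nM

In an ADME assay on PC-3 cells (Homo sapiens) for cytotoxicity, read by CCK-8 assay, with a stated time of 6 days (on this read-out higher numbers stand for weaker inhibition and lower numbers for stronger inhibition), compound 1 returns only a limit, (the limit of > 30000 nM in this assay, at which 1 of the 2 values shown sits), so its standing is known as a bound and not as a number. Compound 2 in this assay gives 5130 nM as a measured number. For the measured compounds named here, no step between these two is counted here; the pair simply shows one number and one limit. Compound 3, `C[C@@H](Cn1ccc(-c2ccc(C#N)c(Cl)c2)n1)Nc1ncnc2nc[nH]c12`, carries a group of 9 heavy atoms (5 carbon, 4 nitrogen; one five-membered aromatic ring with 2 hetero atoms, one six-membered aromatic ring with 2 hetero atoms) in place of a group of 6 heavy atoms (5 carbon, 1 nitrogen; one six-membered aromatic ring with 1 hetero atom), on an amine nitrogen. Going by the values given here, no measured step covers this change, so any expectation rests on the bare pair above. The step from compound 1 to compound 3 is expected to be an at least 3.3-fold lower number from compound 1 to compound 3 (0.52 log units; beyond the scatter), toward stronger inhibition and beyond the scatter, since compound 2 gives 5130 nM with another group on the amine nitrogen. Compound 3 is therefore estimated at 9000 nM, within 2500 nM to 30000 nM, with a real chance that this assay again reports only a limit.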

Compound 3, half-maximal inhibitory concentration: 14100 nM
The estimate for compound 3 lay 1.6-fold (0.19 log units) below the measured number; the range from low to high includes it.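

In this assay, for the compounds shown here, the new group on the amine nitrogen gives an at least 2.1-fold lower number from compound 1 to compound 3 (0.32 log units; beyond the scatter), so a second replacement for pyridin-3-yl at this place, after the one in compound 2, also gives a number within the range of the read-out. Compound 3 gives 14100 nM and compound 2 gives 5130 nM, so the two groups on this nitrogen give different numbers, with the lower one belonging to compound 2. The step from pyridin-3-yl can be stated only as a minimum because compound 1 has a limit and not a number: the limit of > 30000 nM in this assay, at which 1 of the 3 values shown sits.

On these data alone, how far the number would move with a single ring such as phenyl or pyrimidinyl on the same nitrogen stays open. The compounds shown also leave open whether a saturated ring such as piperidine or an open chain such as an ethyl group would give a number at all.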